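This account rests on a few compounds, and the source may have more. Where it says the series, first, only, none or still open, it means among the compounds named here.

Working notes on the series, step from compound 3 to compound 4. Three compounds of the shared core carry a number in a functional assay on HEK293T cells for agonist activity at histamine H2 receptor (Homo sapiens), read by beta-arrestin recruitment; on this read-out lower numbers stand for smaller maximal responses and higher numbers for larger maximal responses. Compound 1 `CCCCCNC(=O)/N=C(\N)NCCCc1sc(N)nc1C` gives 0.15; compound 2 `Cc1nc(N)sc1CCCN/C(N)=N/C(=S)N[C@H](C)c1ccccc1` gives 0.11; compound 3 `Cc1nc(N)sc1CCCN/C(N)=N/C(=O)N[C@@H](C)c1ccccc1` gives 0.46, the highest of the three and beyond the scatter from both others. Among the measured compounds shown here, the one single-point step measured is a number 0.31 higher from compound 1 to compound 3 (beyond the scatter). Compound 2 differs from compound 3 in more than one place, so its value is only set beside that of compound 3 without a step.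

Compound 4 `Cc1nc(N)sc1CCCN/C(N)=N/C(=O)NCc1ccccc1` is the next compound. Its change from compound 3 is hydrogen in place of methyl on a saturated chain carbon bound to an amide-type nitrogen and an aromatic carbon. For the measured compounds named here, no measured step covers this change: the step from pentyl to 1-phenylethyl keeps the phenyl in place for both compound 3 and compound 4 and says nothing about the methyl alone. Since the phenyl-bearing side chain that carried the large gain is retained in compound 4, the expectation is a number close to that of compound 3, with an allowance for a small loss. The estimated step is a number 0.080 lower from compound 3 to compound 4 (within the scatter), within the scatter. For compound 4 the estimate in this assay is 0.38, between 0.2 and 0.55.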

Compound 4, intrinsic activity: the largest response reached, as a fraction of the reference agonist's: 0.33
The estimate for compound 4 lay 0.050 above the measured number, and the stated range covers the measured number.
By their numbers in this assay, from the lowest: compounds 2 and 1 (each within the scatter of the next); then compound 4; then compound 3.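

In this assay the methyl on the saturated chain carbon bound to an amide-type nitrogen and an aromatic carbon matters on its own: the step reads a number 0.13 lower from compound 3 to compound 4 (beyond the scatter) and shows that 1-phenylethyl and benzyl do not give the same maximal response here. Without that methyl, phenyl in place of butyl on the saturated chain carbon still leaves a number 0.18 higher from compound 1 to compound 4 (beyond the scatter) in the same read-out, so part of the rise from the pentyl compound survives in the benzyl compound. Within these three compounds that rise therefore does not rest on the methyl alone, and nothing at hand gives a reason for either step.

Going by these compounds, what remains open is whether an ethyl or a hydroxymethyl on this carbon would raise or lower the response relative to the methyl of compound 3, and whether a fluorine or a methoxy on the phenyl would change the picture. Compound 2 differs from compound 3 in more than one place, so the spatial arrangement of the methyl and the exchange of oxygen for sulfur cannot be separated from these data.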